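The source may hold more compounds than are shown below. What is called first, only, known or untested is meant among the compounds shown, and "the series" means these compounds.

Working notes on a small set of amides sharing one core. Compound 1 `CCS(=O)(=O)Nc1ccc(NC(=O)c2cccc(C(F)(F)F)c2)cc1C` is measured in an ADME assay on HEK293 cells (Homo sapiens) for cytotoxicity, read by MTT assay, with a stated time of 48 h (a lower number here means a stronger inhibitor, a higher number a weaker inhibitor), where compound 1 gives 210000 nM. Compound 2 `CCS(=O)(=O)Nc1ccc(NC(=O)c2cccc(C(F)(F)F)c2)cc1OC` returns only a limit in this assay; in this assay compound 2 gives > 250000 nM. Compound 3 `CS(=O)(=O)Nc1ccc(NC(=O)c2cccc(C(F)(F)F)c2)cc1Cl` likewise returns only a limit; in this assay compound 3 gives > 250000 nM. Going by the values given here, the one step between measured neighbours, an at least 1.1-fold higher number from compound 1 to compound 2 (0.07 log units; that floor lies within the scatter), reaches only the floor set by the limit of > 250000 nM in this assay, at which 2 of the 3 values shown sit, and is not resolved beyond the scatter. Compound 3 thus stands at the limit, alongside compound 2, and no difference from compound 1 beyond the scatter can be read for either of them.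

Compound 4 `CCS(=O)(=O)Nc1ccc(NC(=O)c2cccc(C(F)(F)F)c2)cc1Cl` differs from compound 3 by methyl in place of hydrogen on a saturated chain carbon bound to a sulfonyl sulfur. Among the compounds with values here, no measured step touches the group on the sulfonyl sulfur; the only measured step, an at least 1.1-fold higher number from compound 1 to compound 2 (0.07 log units; that floor lies within the scatter), concerns a group on an aromatic carbon and stays within the scatter. Nothing in the measured values points to a shift in this assay beyond the scatter for this change, so the expected step is a number no higher from compound 3 to compound 4 (the limit leaves the size open). Compound 4 is accordingly expected to give 250000 nM in this assay, with a range from 150000 nM to 500000 nM, and most likely to come back as a limit rather than a number.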

Compound 4, half-maximal inhibitory concentration: 159000 nM
Beside the measured number, compound 4's estimate is 1.6-fold (0.20 log units) above it; the range from low to high includes it.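

Going by these compounds alone, compound 4 gives the first measured step on the group at the sulfonyl sulfur, methylsulfonyl to ethylsulfonyl, and it reads an at least 1.5-fold lower number from compound 3 to compound 4 (0.19 log units; that floor lies within the scatter) in this assay. With the ethylsulfonyl group held fixed, the aromatic carbon now has three substituents compared directly, and neither comparison with chloro separates the compounds beyond the scatter: an at least 1.5-fold lower number from compound 2 to compound 4 (0.19 log units; that floor lies within the scatter), and a 1.3-fold lower number from compound 1 to compound 4 (0.12 log units; within the scatter). The true size of the steps from compound 2 and compound 3 stays undetermined, and neither change can be called a real shift, because both of those compounds sit at the ceiling of the read-out: the limit of > 250000 nM in this assay, at which 2 of the 4 values shown sit.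

As far as these compounds go, whether a longer chain such as propyl on the sulfonyl sulfur, or a carboxylic acid or an amine on the aromatic carbon, would move the number beyond the scatter remains open. Also open, from the compounds shown here alone, is whether any change to the trifluoromethyl group on the benzoyl side of the amide would shift the number in this assay, since that group is the same in all four compounds.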